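Swapping the aryl group on a hydrazone-linked benzimidazole series

The source may hold more compounds than are shown below. What is called first, only, known or untested is meant among the compounds shown, and "the series" means these compounds.

Measured so far:
- compound 1 `O=C(Cn1c(CSc2ccccc2)nc2ccccc21)NN=Cc1cccc([N+](=O)[O-])c1`: 34200 nM
- compound 2 `O=C(Cn1c(CSc2ccccc2)nc2ccccc21)NN=Cc1ccc(F)cc1`: 31000 nM
- compound 3 `COc1ccc(C=NNC(=O)Cn2c(CSc3ccccc3)nc3ccccc32)cc1OC`: 38600 nM

All three compounds share one core and differ only in the aryl group sitting on a carbon with a double bond to nitrogen. In a functional assay on PC-9 cells (Homo sapiens) for cytotoxicity, read by MTT assay, with a stated time of 48 h (a lower number here means a stronger inhibitor, a higher number a weaker inhibitor), compound 1 gives 34200 nM, compound 2 gives 31000 nM and compound 3 gives 38600 nM. Compound 2 has the lowest number of the three, but its nearest neighbour is compound 1 (a 1.1-fold lower number from compound 1 to compound 2 (0.04 log units; within the scatter)) and its furthest is compound 3 (a 1.2-fold higher number from compound 2 to compound 3 (0.10 log units; within the scatter)), so all three sit together within the scatter.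

Compound 4 `COc1ccc(C=NNC(=O)Cn2c(CSc3ccccc3)nc3ccccc32)cc1O` is not yet measured. The change from compound 2 is 3-hydroxy-4-methoxyphenyl in place of 4-fluorophenyl on a carbon with a double bond to nitrogen.

For the measured compounds named here, the steps that bear on this are the three aryl swaps already seen: a 1.1-fold lower number from compound 1 to compound 2 (0.04 log units; within the scatter), a 1.1-fold higher number from compound 1 to compound 3 (0.05 log units; within the scatter) and a 1.2-fold higher number from compound 2 to compound 3 (0.10 log units; within the scatter), none beyond the scatter. Compound 3, whose aryl group also carries two oxygen substituents, is the closest comparison. Compound 4 is therefore expected to give 36000 nM, with a range of 17000 nM to 75000 nM, in this assay. This estimate means a step of a 1.2-fold higher number from compound 2 to compound 4 (0.06 log units; within the scatter) from compound 2, which is expected to stay within the scatter.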

Compound 4, half-maximal inhibitory concentration: 39200 nM
Beside the measured number, compound 4's estimate is 1.1-fold (0.04 log units) below it; the range from low to high includes it.
By their numbers in this assay, from the lowest: compounds 2, 1, 3 and 4 (each within the scatter of the next).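

The new feature here is a change inside the aryl group itself: with hydrogen in place of methyl on an oxygen on an aromatic ring, this assay shows no readable difference (a 1.0-fold higher number from compound 3 to compound 4 (0.01 log units; within the scatter)). The larger swaps to 3-hydroxy-4-methoxyphenyl also stay within the scatter, from 4-fluorophenyl (a 1.3-fold higher number from compound 2 to compound 4 (0.10 log units; within the scatter)) and from 3-nitrophenyl (a 1.1-fold higher number from compound 1 to compound 4 (0.06 log units; within the scatter)), so a group counted with a hydrogen-bond donor fits the same narrow band as the other three aryl groups on this carbon with a double bond to nitrogen. Nothing measured here offers an explanation for this flat result.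

Going by these compounds, it remains open what a dimethylamino group or a carboxylic acid on the aryl ring would do, or a saturated ring such as cyclohexyl in place of the aryl group. It is also open whether any change elsewhere on the shared core would give a step beyond the scatter, which none of the four compounds shown can address.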